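Changing One Aryl Group on a Shared Core

A few compounds are considered here, and "the series" means these few. Any claim that something is new, unique, unknown or untested is made for them only; others in the source may bear on it.

compound 1 `O=C1C(=Cc2ccc(O)cc2)C(=O)N(c2ccc(Cl)cc2)N1c1ccc(Cl)cc1` gives 19500 nM
compound 2 `COc1cccc(C=C2C(=O)N(c3ccc(Cl)cc3)N(c3ccc(Cl)cc3)C2=O)c1O` gives 24300 nM

In a functional assay on MGC-803 cells (Homo sapiens) for cytotoxicity, read by MTT assay, with a stated time of 72 h (on this read-out higher numbers stand for weaker inhibition and lower numbers for stronger inhibition), compound 2 gives 24300 nM and lies within the usual scatter of compound 1. Compound 3 `O=C1C(=Cc2cccc(Cl)c2)C(=O)N(c2ccc(Cl)cc2)N1c1ccc(Cl)cc1` differs from compound 2 by 3-chlorophenyl in place of 2-hydroxy-3-methoxyphenyl on a double-bonded chain carbon bound to a double-bonded ring carbon and in nothing else. Among the measured compounds shown here, the one measured step at this place is a 1.2-fold higher number from compound 1 to compound 2 (0.10 log units; within the scatter) and it stays within the scatter, so no step beyond the scatter is expected in this assay here. For the measured compounds named here, no measured compound carries 3-chlorophenyl at this place, and the range is kept wide. The expected step is a 1.2-fold lower number from compound 2 to compound 3 (0.08 log units; within the scatter) in size. Compound 3 is estimated at 20000 nM with 8000 nM to 50000 nM as the expected range.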

Compound 3, half-maximal inhibitory concentration: 14400 nM
Estimate against measurement, compound 3: 1.4-fold (0.14 log units) above; low and high end bracket the measured number.
By their numbers in this assay, from the lowest: compounds 3, 1 and 2 (each within the scatter of the next).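

In this assay, 3-chlorophenyl at this place gives a 1.7-fold lower number from compound 2 to compound 3 (0.23 log units; within the scatter) and a 1.4-fold lower number from compound 1 to compound 3 (0.13 log units; within the scatter). Among these three compounds, then, a hydroxy group on this aromatic ring is not required for a number in this range, since 3-chlorophenyl has 0 hydrogen-bond donors and still matches 4-hydroxyphenyl and 2-hydroxy-3-methoxyphenyl within the scatter. Nothing available explains why these numbers stay so close.

The compounds shown leave open whether an amine, a carboxylic acid or a longer chain at this place would give a step beyond the scatter. Going by these compounds, whether a change elsewhere on the shared core would do so also remains open.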